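A few compounds are considered here, and "the series" means these few. Any claim that something is new, unique, unknown or untested is made for them only; others in the source may bear on it.

Measured compounds:
compound 1, `C=C(C)C(CCC/C=C(\c1ccccc1)c1cccnc1)C(=O)O`, 28 nM
compound 2, `O=C(O)CCCC/C=C(\c1cccnc1)c1cccc(Br)c1`, 180 nM
compound 3, `COC(=O)CCCC/C=C(\c1ccccc1)c1cccnc1`, 100 nM

In an assay (Equus caballus) for inhibition of Thromboxane-A synthase (Homo sapiens), using microsomes (on this read-out higher numbers stand for weaker inhibition and lower numbers for stronger inhibition), compound 2 gives the highest of the three numbers. Compound 3 lies nearest to it, with a number that sits within the scatter of compound 2, so no order can be read between these two. Compound 1 lies furthest away, with a number beyond the scatter below that of compound 2. Among the measured compounds shown here, the one step that can be traced between two measured compounds is a 3.6-fold higher number from compound 1 to compound 3 (0.55 log units; beyond the scatter), and it touches the acid end of the chain, not the aromatic rings.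

Compound 4, `O=C(O)CCCC/C=C(\c1cccnc1)c1ccccc1Br`, has not yet been measured in this assay. It differs from compound 2 in this way: 2-bromophenyl in place of 3-bromophenyl on a double-bonded chain carbon bound to an aromatic carbon and a double-bonded chain carbon. For the measured compounds named here, no measured step bears on a move of the bromine within the bromophenyl group; the only recorded step concerns a different part of the molecule. With nothing to guide the direction, the expected change from compound 2 is a step of about a 1.4-fold higher number from compound 2 to compound 4 (0.14 log units; within the scatter), which is not beyond the scatter. Compound 4 is therefore estimated at 250 nM, with a range from 80 nM to 800 nM.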

Compound 4, half-maximal inhibitory concentration: 130 nM
Beside the measured number, compound 4's estimate is 1.9-fold (0.28 log units) above it; the range from low to high includes it.
By their numbers in this assay, from the lowest: compound 1; then compounds 3, 4 and 2 (each within the scatter of the next).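

Among the compounds shown here, compound 4 gives the first measured step at the aromatic end of these molecules, as the only earlier step concerned the acid end of the chain. With 2-bromophenyl in place of 3-bromophenyl on a double-bonded chain carbon bound to an aromatic carbon and a double-bonded chain carbon, this assay shows a 1.4-fold lower number from compound 2 to compound 4 (0.14 log units; within the scatter) and so does not separate these two bromine placements, which means no preference between them can be read from this pair. Nothing available here accounts for this outcome.

The compounds shown leave open whether the same closeness would hold for other groups in this place, such as a chlorophenyl or a methoxyphenyl group on the same chain with its free carboxylic acid. For the compounds shown here, they also leave open whether either bromine placement would behave in the same way on a compound carrying the 1-carboxy-2-methylprop-2-en-1-yl end of compound 1, or on a methyl ester like compound 3, since the one pair measured here has a single acid chain.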